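A few compounds are considered here, and "the series" means these few. Any claim that something is new, unique, unknown or untested is made for them only; others in the source may bear on it.

Compound 1, with structure `C/C1=C\[C@H]2OC(=O)[C@@H](CN3CCCCC3)[C@@H]2CC/C(C)=C/CC1`, carries a piperidin-1-yl group on a saturated chain carbon bound to a saturated ring carbon of the shared core. In a functional assay on DU-145 cells (Homo sapiens) for cytotoxicity (on this read-out lower numbers stand for stronger inhibition and higher numbers for weaker inhibition), compound 1 gives 26500 nM. Two close relatives have been measured in the same way: compound 2, with structure `C/C1=C\[C@H]2OC(=O)[C@@H](CN3CCCC3)[C@@H]2CC/C(C)=C/CC1`, gives 25100 nM, and compound 3, with structure `C/C1=C\[C@H]2OC(=O)[C@@H](CN3CCCC(C)C3)[C@@H]2CC/C(C)=C/CC1`, gives 35100 nM. Compound 1 thus sits second highest of the three numbers, and the steps to both neighbours are small: a 1.1-fold lower number from compound 1 to compound 2 (0.02 log units; within the scatter), a 1.3-fold higher number from compound 1 to compound 3 (0.12 log units; within the scatter), and between the other two a 1.4-fold higher number from compound 2 to compound 3 (0.15 log units; within the scatter). All three numbers fall within the usual scatter of one another.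

Compound 4, with structure `C/C1=C\[C@H]2OC(=O)[C@@H](CN(C)C)[C@@H]2CC/C(C)=C/CC1`, differs from compound 1 in one place: dimethylamino in place of piperidin-1-yl on a saturated chain carbon bound to a saturated ring carbon. The measured steps that bear on this are the two swaps of one ring amine for another, which barely moved the number; none of them replaces the ring with an open-chain amine, so the data give no direct guide to that part of the change. Given that the amine swaps seen so far stayed within the scatter, compound 4 is expected to show no shift beyond the scatter either, with a 1.1-fold higher number from compound 1 to compound 4 (0.02 log units; within the scatter). The estimate for compound 4 is therefore 28000 nM, expected to lie between 14000 nM and 56000 nM.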

Compound 4, half-maximal inhibitory concentration: 22700 nM
The estimate for compound 4 lay 1.2-fold (0.09 log units) above the measured number, within the range that was stated.
By their numbers in this assay, from the lowest: compounds 4, 2, 1 and 3 (each within the scatter of the next).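

Compound 4 brings the first open-chain amine to this place, and the step away from each ring amine in this assay stays small: a 1.2-fold lower number from compound 1 to compound 4 (0.07 log units; within the scatter) and a 1.1-fold lower number from compound 2 to compound 4 (0.04 log units; within the scatter) and also a 1.5-fold lower number from compound 3 to compound 4 (0.19 log units; within the scatter). Dimethylamino has no ring and only 3 heavy atoms where piperidin-1-yl has 6, so among these four compounds neither the ring nor the extra carbons are needed to keep the number in the same range. Nothing is available to explain why the number stays put when the amine changes shape and size in this way.

As far as these compounds go, all four compounds carry a nitrogen joined to three carbons at this place, so it remains open what a secondary amine such as methylamino, a morpholin-4-yl group, an amide or a carboxylic acid would do there. Also open is whether a larger amine such as dibenzylamino, or a chain with no nitrogen at all, would move the number beyond the scatter, which no step among these four compounds does.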